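Trimming a Ring Substituent from Ethyl to Methyl

A few compounds are considered here, and "the series" means these few. Any claim that something is new, unique, unknown or untested is made for them only; others in the source may bear on it.

Compound 1 `CC/C=C/[C@H](CC)C[C@@]1(C)C[C@@H](CC)[C@@H](CC(=O)OC)OO1`: 9.8 ug/mL in a functional assay on SF-295 cells (Homo sapiens) for cytotoxicity; a higher number here means a weaker inhibitor, a lower number a stronger inhibitor
Compound 2 `CC/C=C/[C@H](CC)C/C(=C/[C@@]1(CC)C[C@H](CC)[C@H](CC(=O)O)OO1)CC`: "not determined" (no result reported)
Compound 3 `CC/C=C/[C@H](CC)C[C@]1(CC)C=C(CC)/C(=C/C(=O)OC)O1`: 11.4 ug/mL

Two compounds carry numbers. In this assay compound 1 gives 9.8 ug/mL and compound 3 gives 11.4 ug/mL; the two lie within the scatter of each other and cannot be told apart. For compound 2 the entry in this assay reads "not determined" (no result reported), so no number was obtained.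

Compound 4 `CC/C=C/[C@H](CC)C[C@]1(C)C=C(CC)/C(=C/C(=O)OC)O1` differs from compound 3 by hydrogen in place of methyl on a saturated chain carbon bound to a saturated ring carbon. Within the data shown here, no measured pair isolates this change, and the pair compound 1 against compound 3 differs in several places at once while still giving numbers within the scatter. A step of no size beyond the scatter is expected, in no particular direction, a 1.0-fold lower number from compound 3 to compound 4 (0.02 log units; within the scatter). Compound 4 is therefore estimated at 11 ug/mL, between 5 ug/mL and 25 ug/mL.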

Compound 4, half-maximal inhibitory concentration: > 25 ug/mL
Compound 4: no number, only a limit; the forecaster's own chance of this, stated with the estimate: 10%; middle value at least 2.2-fold (0.35 log units) from the limit.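

Trimming the ethyl on the saturated ring carbon to methyl gives, in this assay, an at least 2.1-fold higher number from compound 3 to compound 4 (0.34 log units; beyond the scatter). This is the only pair shown that isolates this position, and it shows that even so small a trim there is not neutral. The entry for compound 4 is a limit and not a number: the limit of > 25 ug/mL in this assay, at which 1 of the 4 values shown sits.

How far compound 4 truly lies past that limit cannot be read. Going by these compounds, whether a longer chain such as propyl, or an amine, in this place would keep or improve the value of compound 3 also stays open.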